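A few compounds are considered here, and "the series" means these few. Any claim that something is new, unique, unknown or untested is made for them only; others in the source may bear on it.

Measured in a functional assay (microsomes, liver) with Rattus norvegicus as the target; on this read-out lower numbers stand for stronger inhibition and higher numbers for weaker inhibition
- compound 1 `Cc1c(C)c2c(c(C)c1N)CC(C)(CSc1ccc(F)cc1)O2` gives 220 nM
- compound 2 `Cc1c(C)c2c(c(C)c1N)CC(C)(CSc1ccc(O)cc1)O2` gives 220 nM
- compound 3 `CCCSCC1(C)Cc2c(C)c(N)c(C)c(C)c2O1` gives 280 nM

Compound 3 cannot be told apart from the other two, and no change at the digits printed from compound 1 to compound 2 (within the scatter) separates those two in the same way. The next change leads to compound 4 `Cc1c(C)c2c(c(C)c1N)CC(C)(CBr)O2` and is bromo in place of propylsulfanyl on a saturated chain carbon bound to a saturated ring carbon in words bromo in place of propylsulfanyl on a saturated chain carbon bound to a saturated ring carbon.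

For the measured compounds named here, two measured steps bear on it, since both change the group on the sulfur. They are a 1.3-fold higher number from compound 1 to compound 3 (0.10 log units; within the scatter) and a 1.3-fold higher number from compound 2 to compound 3 (0.10 log units; within the scatter) and neither lies beyond the scatter. Neither removes the sulfur, so no measurement in this small set covers a bromo group at this place, and the range has to stay wide. No step beyond the scatter is expected in this assay for this change. The expected step is no change at the digits printed from compound 3 to compound 4 (within the scatter) in this read-out. For compound 4 the estimated value is 280 nM with an expected range from 100 nM to 800 nM in this read-out.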

Compound 4, half-maximal inhibitory concentration: 300 nM
For compound 4 the middle estimate is 1.1-fold (0.03 log units) below the measured one, within the range that was stated.
By their numbers in this assay, from the lowest: compounds 1, 2, 3 and 4 (each within the scatter of the next).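

In this assay, replacing the whole propylsulfanyl group with bromo on this saturated chain carbon bound to a saturated ring carbon gives a 1.1-fold higher number from compound 3 to compound 4 (0.03 log units; within the scatter). Earlier steps changed only the group on the sulfur, whereas this one removes the sulfur itself, and the read-out of compound 4 still cannot be told apart from that of compound 3. Within this pair, the sulfur is therefore not needed to keep the number at this level, and no information is available to explain this result.

As far as these compounds go, whether an amine, a carboxylic acid or a longer chain on this carbon would also leave the number within the scatter remains open. All the compounds shown keep the shared core intact, so the response to changes in the core also remains open.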